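A few compounds are considered here, and "the series" means these few. Any claim that something is new, unique, unknown or untested is made for them only; others in the source may bear on it.

In a functional assay on SGC-7901 cells (Homo sapiens) for cytotoxicity, read by MTT assay, with a stated time of 48 h (a lower number here means a stronger inhibitor, a higher number a weaker inhibitor), compound 1 `CCN(CC)c1ccc2cc(C(=O)c3ccc(N4CCN(C(=O)CN5CCNCC5)CC4)cc3)oc2c1` gives 1220 nM. Compound 2 `CCN(CC)c1ccc2cc(C(=O)c3ccc(N4CCN(C(=O)CN5CCN(C(=O)/C=C/c6ccccc6)CC5)CC4)cc3)oc2c1` gives 1140 nM in this assay, and the step of a 1.1-fold lower number from compound 1 to compound 2 (0.03 log units; within the scatter) comes from placing a (2-phenylethenyl)carbonyl on the ring amine nitrogen. Compound 3 `CCN(CC)c1ccc2cc(C(=O)c3ccc(N4CCN(C(=O)CN5CCN(S(=O)(=O)c6ccc(C#N)cc6)CC5)CC4)cc3)oc2c1` reaches only a limit of the assay, reported as > 40000 nM. This is the limit at which one of the three values shown sits (the limit of > 40000 nM in this assay, at which 1 of the 3 values shown sits). Both steps leading into compound 3 are large, an at least 32-fold higher number from compound 1 to compound 3 (1.51 log units; beyond the scatter) and an at least 35-fold higher number from compound 2 to compound 3 (1.54 log units; beyond the scatter), so with its (4-cyanophenyl)sulfonyl on that nitrogen compound 3 is the weakest of the three measured compounds.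

Compound 4 `CCN(CC)c1ccc2cc(C(=O)c3ccc(N4CCN(C(=O)CN5CCN(S(=O)(=O)c6ccc(F)cc6)CC5)CC4)cc3)oc2c1` keeps the sulfonyl group and alters only its outer end: fluoro in place of cyano on an aromatic carbon. Within the data shown here, no measured pair shows fluoro in place of cyano, so the two large steps into compound 3 are the only guide, and both concern the whole sulfonyl group, which compound 4 retains. The change at the far end of that group is therefore expected to move the number little, and the step of an at least 1.3-fold lower number from compound 3 to compound 4 (0.12 log units; that floor lies within the scatter) is estimated to be small, with the result likely still close to the limit. Compound 4 is accordingly expected to give about 30000 nM, within a range from 8000 nM to 80000 nM.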

Compound 4, half-maximal inhibitory concentration: > 40000 nM
Compound 4: no number, only a limit; the forecaster's own chance of this, stated with the estimate: 60%; at least 1.3-fold (0.12 log units) between middle value and limit.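

The large weakening seen with (4-cyanophenyl)sulfonyl on the ring amine nitrogen does not depend on the cyano group alone, since (4-fluorophenyl)sulfonyl there gives an at least 32-fold higher number from compound 1 to compound 4 (1.51 log units; beyond the scatter) and an at least 35-fold higher number from compound 2 to compound 4 (1.54 log units; beyond the scatter). In this assay compound 4 gives > 40000 nM, which is a limit of the assay and not a number. Compound 3 also stands at a limit, so the step between these two cannot be read and neither cyano nor fluoro can be ranked ahead of the other: the limit of > 40000 nM in this assay, at which 2 of the 4 values shown sit.

Going by these compounds, it stays open whether the weak result goes with the sulfonyl link or with the substituted phenyl ring it carries; a methylsulfonyl group on that nitrogen, or a 4-fluorobenzoyl group, would separate the two. Also open, on these data alone, is whether an amine or a carboxylic acid in place of the fluoro would bring a sulfonyl compound back to a readable number in this assay.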